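Swapping the heteroaryl arm of a weak transporter inhibitor

A few compounds are considered here, and "the series" means these few. Any claim that something is new, unique, unknown or untested is made for them only; others in the source may bear on it.

Measured so far:
Compound 1, `COc1ccnc(C[S+]([O-])C(c2ccccc2)c2ccccc2)c1OC`: "not active" (no number reported)
Compound 2, `[O-][S+](Cc1cccs1)C(c1ccc(F)cc1)c1ccc(F)cc1`: 4000 nM
Compound 3, `CC(C)c1nnsc1C[S+]([O-])C(c1ccccc1)c1ccccc1`: 69100 nM

Three compounds share a sulfoxide that links a diaryl methine to a heteroaryl methyl arm, and they have been tested in an assay on HEK293 cells for inhibition of sodium-dependent dopamine transporter (Homo sapiens), read by scintillation counting, with stated times of 5 min and 1 min; a higher number here means a weaker inhibitor, a lower number a stronger inhibitor. Compound 1 gave no number in this assay, being reported as "not active" (no number reported). Compound 2 gives 4000 nM, while compound 3 gives 69100 nM, the highest of the two numbers and far above compound 2, well beyond the scatter.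

Compound 4, `Cc1cnc(C[S+]([O-])C(c2ccccc2)c2ccccc2)nc1`, has not yet been measured. It differs from compound 3 in one place: 5-methylpyrimidin-2-yl in place of 4-isopropyl-1,2,3-thiadiazol-5-yl on a saturated chain carbon bound to a sulfur. Among the measured compounds shown here, no pair of measured compounds differing in only one spot is available to calibrate this change. Compound 1, which also carries a six-membered azine on this arm, gave no number at all, so the expectation for compound 4 stays in the weak range. Compound 4 is expected to give 35000 nM, within 8000 nM to 150000 nM. The expected step is a 2.0-fold lower number from compound 3 to compound 4 (0.30 log units; within the scatter), a modest drop in the number that may not exceed the scatter.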

Compound 4, half-maximal inhibitory concentration: 156000 nM
For compound 4 the middle estimate is 4.5-fold (0.65 log units) below the measured one, outside the stated range (above it).
By their numbers in this assay, from the lowest: compound 2; then compound 3; then compound 4.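

In this assay, replacing the 4-isopropyl-1,2,3-thiadiazol-5-yl arm with the 5-methylpyrimidin-2-yl arm gives a 2.3-fold higher number from compound 3 to compound 4 (0.35 log units; beyond the scatter). Among the compounds shown here, this is the first reading of a single change at this place, on a saturated chain carbon bound to a sulfur, and it shows that the arm can shift the number, though only modestly here. The swap alters the ring size, the hetero atoms and the alkyl group all at once, and nothing available separates their contributions.

On these data alone, it remains open how an arm ending in an amine or a carboxylic acid would read on the core of compound 4. A plain phenyl ring on that arm would also show whether any hetero atom in the ring matters in this assay.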